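Swapping the Pyridine Ester Acyl Group for a Furan Ester

The compounds below may be only part of what the source reports. "The series", "measured", "known", "first", "only" and "open" are said of these compounds alone.

Compound 1 `C=C1CC[C@@H]2[C@](C)(COC(=O)c3cccnc3)[C@H](O)CC[C@@]2(C)[C@@H]1/C=C/C1=CCOC1=O` and compound 2 `C=C1CC[C@@H]2[C@](C)(COC(=O)c3ccco3)[C@H](O)CC[C@@]2(C)[C@@H]1/C=C/C1=CCOC1=O` share one core and differ by furan-2-yl in place of pyridin-3-yl on a carbonyl carbon. In an ADME assay on HepG2 2.2.15 cells (Homo sapiens) for cytotoxicity, read by MTT assay (a lower number here means that less compound is tolerated, a higher number that more compound is tolerated), compound 1 gives 113000 nM, and compound 2 gives 92000 nM; the step is a 1.2-fold lower number from compound 1 to compound 2 (0.09 log units; within the scatter). Compound 3 `C=C1CC[C@@H]2[C@](C)(COC(=O)c3cccnc3)[C@H](O)CC[C@@]2(C)[C@@H]1C/C=C1\C=COC1=O` keeps the (pyridin-3-yl)carbonyl group on a core that differs from that of compound 1 by a group of 8 heavy atoms (6 carbon, 2 oxygen; one five-membered non-aromatic ring with 1 hetero atom) in place of a group of 8 heavy atoms (6 carbon, 2 oxygen; one five-membered non-aromatic ring with 1 hetero atom), on a saturated ring carbon. In this assay compound 3 gives 2050000 nM, which is an 18-fold higher number from compound 1 to compound 3 (1.26 log units; beyond the scatter). Compound 4 `C=C1CC[C@@H]2[C@](C)(COC(=O)c3ccco3)[C@H](O)CC[C@@]2(C)[C@@H]1C/C=C1\C=COC1=O` has not yet been measured; it differs from compound 3 by furan-2-yl in place of pyridin-3-yl on a carbonyl carbon, the same change as that between compound 1 and compound 2, made at the same place. That change earlier gave a 1.2-fold lower number from compound 1 to compound 2 (0.09 log units; within the scatter). On that basis the step is expected to be a 1.2-fold lower number from compound 3 to compound 4 (0.08 log units; within the scatter). In this assay compound 4 is estimated at 1700000 nM, with a likely range from 700000 nM to 4000000 nM.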

Compound 4, half-maximal cytotoxic concentration: > 2150000 nM
Compound 4: no number, only a limit; the forecaster's own chance of this, stated with the estimate: 25%; at least 1.2-fold (0.10 log units) between middle value and limit.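

In this assay compound 4 reads > 2150000 nM, which is a limit of the assay and not a number. The step for furan-2-yl in place of pyridin-3-yl on a carbonyl carbon is an at least 1.0-fold higher number from compound 3 to compound 4 (0.02 log units; that floor lies within the scatter), so the two cores can be compared only up to that limit: the same change on two cores in this assay, a 1.2-fold lower number (0.09 log units; within the scatter) from compound 1 to compound 2 and an at least 1.0-fold higher number (0.02 log units; that floor lies within the scatter) from compound 3 to compound 4; the limit leaves it open whether they differ. The core change, read with the furan ester, is an at least 23-fold higher number from compound 2 to compound 4 (1.36 log units; beyond the scatter), so it points the same way with both esters, though its size remains unsettled: the same change on two cores in this assay, an 18-fold higher number (1.26 log units; beyond the scatter) from compound 1 to compound 3 and an at least 23-fold higher number (1.36 log units; beyond the scatter) from compound 2 to compound 4; the limit leaves it open whether they differ.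

The compounds shown leave open how far compound 4 lies past its limit, and so what the ester swap does on this core. They also leave open how an acetyl or benzoyl ester, or an amine in place of the ester, would read on either core.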